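The source may hold more compounds than are shown below. What is called first, only, known or untested is meant among the compounds shown, and "the series" means these compounds.

Working notes on the series.

Compound 1 `COc1cc(/C=C/c2ccc(OC(=O)/C=C/c3ccccc3)cc2)cc(OC)c1` and compound 2 `COc1cc(/C=C/c2ccc(OC(=O)/C=C/c3ccc([N+](=O)[O-])cc3)cc2)cc(OC)c1` share one core and differ only at the outer aromatic ring. In a functional assay on MDA-MB-231 cells (Homo sapiens) for inhibition, read by MTT assay, with a stated time of 48 h (a higher number here means a weaker inhibitor, a lower number a stronger inhibitor), compound 1 gives 9810 nM, and compound 2 gives 18000 nM. For the measured compounds named here, the only step measured so far, nitro in place of hydrogen on an aromatic carbon, reads a 1.8-fold higher number from compound 1 to compound 2 (0.26 log units; within the scatter); compound 2 therefore holds the higher of the two numbers, though its gap to compound 1 lies within the scatter.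

Compound 3 `COc1cc(/C=C/c2ccc(OC(=O)/C=C/c3ccc(F)cc3)cc2)cc(OC)c1` follows from compound 2 by fluoro in place of nitro on an aromatic carbon. Going by the values given here, no measured pair shows a nitro-to-fluoro exchange; the one step that bears on the site is the hydrogen-to-nitro step, which was itself small. A number near compound 2, or somewhat closer to compound 1, is expected, with the step of a 1.5-fold lower number from compound 2 to compound 3 (0.18 log units; within the scatter) expected to stay within the scatter. In this assay compound 3 is expected at 12000 nM, between 5000 nM and 30000 nM.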

Compound 3, half-maximal inhibitory concentration: 6210 nM
Compound 3: the middle estimate sits 1.9-fold (0.29 log units) above what was measured; the measured number falls inside the stated range.
By their numbers in this assay, from the lowest: compounds 3, 1 and 2 (each within the scatter of the next, the first and the last beyond it).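

In this assay, for the compounds shown here, the change from 4-nitrophenyl to 4-fluorophenyl gives the first step at this site that lies beyond the scatter (a 2.9-fold lower number from compound 2 to compound 3 (0.46 log units; beyond the scatter)), so the choice of group on this aromatic carbon can register in the read-out, though only modestly. Against hydrogen, fluoro gives a step within the scatter (a 1.6-fold lower number from compound 1 to compound 3 (0.20 log units; within the scatter)), as nitro did, so the two substituted compounds separate from each other while neither separates from compound 1. Nothing at hand explains the gap between nitro and fluoro.

The compounds shown leave open how an amine, a methoxy group or a carboxylic acid on this carbon would read against compound 1. On these data alone, whether any group at this site can move the number beyond the scatter from that of compound 1 also stays open.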